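The source may hold more compounds than are shown below. What is called first, only, known or untested is meant among the compounds shown, and "the series" means these compounds.

Compound 1 `C=C1CCC[C@]2(C)CCC(c3cn(-c4ccc(OC)cc4)nn3)=CC[C@@]12C`: 43600 nM
Compound 2 `C=C1CCC[C@]2(C)CCC(c3cn(-c4ccccc4C(C)=O)nn3)=CC[C@@]12C`: 55700 nM
Compound 3 `C=C1CCC[C@]2(C)CCC(c3cn(-c4ccc(Cl)cc4)nn3)=CC[C@@]12C`: 18800 nM

In a functional assay on HeLa cells (Homo sapiens) for cytotoxicity, read by MTT assay, with a stated time of 48 h (a higher number here means a weaker inhibitor, a lower number a stronger inhibitor), compound 3 has the lowest number of the three, at 18800 nM. Compound 4 `C=C1CCC[C@]2(C)CCC(c3cn(-c4ccc(C)cc4)nn3)=CC[C@@]12C` differs from it by one swap, methyl in place of chloro on an aromatic carbon. The closest measured guide is the swap of methoxy for chloro, a 2.3-fold lower number from compound 1 to compound 3 (0.37 log units; beyond the scatter), a modest step. The broader change of the whole ring substituent, a 3.0-fold lower number from compound 2 to compound 3 (0.47 log units; beyond the scatter), is also modest. The step of a 1.3-fold higher number from compound 1 to compound 2 (0.11 log units; within the scatter) does not involve chloro and says little here. Losing chloro is therefore expected to bring a modest rise in the number. Compound 4 is estimated at about 30000 nM, with an expected range of 15000 nM to 58000 nM. This estimate means an expected 1.6-fold higher number from compound 3 to compound 4 (0.20 log units; within the scatter).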

Compound 4, half-maximal inhibitory concentration: 69100 nM
For compound 4 the middle estimate is 2.3-fold (0.36 log units) below the measured one; measured number outside the range, above it.
By their numbers in this assay, from the lowest: compound 3; then compounds 1, 2 and 4 (each within the scatter of the next).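

Para to a large group, chloro and methyl carry the same count of heavy atoms, yet in this assay the swap gives a 3.7-fold higher number from compound 3 to compound 4 (0.57 log units; beyond the scatter) and so does not preserve the value of compound 3. Methyl instead joins the other substituents, with a 1.6-fold higher number from compound 1 to compound 4 (0.20 log units; within the scatter) and a 1.2-fold higher number from compound 2 to compound 4 (0.09 log units; within the scatter) both small steps, which leaves compound 3 alone at the low end of the four. No measured evidence here explains this difference. From the compounds shown here alone, whether bromo, an amine or a carboxylic acid at this place would match chloro or methyl remains open.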